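Removing one fluorine from the aryl group of compound 2

The source may report more compounds than this note shows. Statements on the series, on what has been measured and on what is new or still open speak of the compounds shown alone.

Of the compounds shown here, two built on a shared core have been measured in an assay on isolated protein for agonist activity at Free fatty acid receptor 1 (Homo sapiens); a higher number here means that more compound is needed for the effect, a lower number that less compound is needed. Compound 1 `CC#CC(CC(=O)O)c1ccc(OCc2ccn3cc(-c4ccc(C(C)C)cc4)nc3c2)cc1` gives 615 nM. Compound 2 `CC#CC(CC(=O)O)c1ccc(OCc2ccn3cc(-c4ccc(F)cc4F)nc3c2)cc1` gives 792 nM. The step of a 1.3-fold higher number from compound 1 to compound 2 (0.11 log units; within the scatter) shows that exchanging the whole aryl group left the result within the scatter, so compound 2 stands beside compound 1 with no separation that the assay can resolve.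

Compound 3 `CC#CC(CC(=O)O)c1ccc(OCc2ccn3cc(-c4ccc(F)cc4)nc3c2)cc1` differs from compound 2 by a smaller change: hydrogen in place of fluoro on an aromatic carbon. Among the measured compounds shown here, no measured step removes a single fluorine, so the only guidance is the aryl swap from compound 1 to compound 2, which changed little. A change that removes one fluorine is therefore expected to stay within the scatter in this assay, in no particular direction, expected as a 1.1-fold lower number from compound 2 to compound 3 (0.02 log units; within the scatter). For compound 3 the estimate is 750 nM, with a range from 350 nM to 1600 nM.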

Compound 3, half-maximal effective concentration: 783 nM
Compound 3: middle estimate off by 1.0-fold (0.02 log units), on the low side; the range from low to high includes it.
By their numbers in this assay, from the lowest: compounds 1, 3 and 2 (each within the scatter of the next).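

In this assay, hydrogen in place of the fluoro group ortho to a large group gives a 1.0-fold lower number from compound 2 to compound 3 (0.00 log units; within the scatter), so this single atom can be removed with no difference that the assay can resolve. Fluoro in place of isopropyl on an aromatic carbon gives a 1.3-fold higher number from compound 1 to compound 3 (0.10 log units; within the scatter), so these two groups of very different size cannot be told apart here, and the three aryl groups shown all read alike. No supporting data explain why these groups give such similar results.

Still open, as far as these compounds go, is whether a plain phenyl group, or an amine or a carboxylic acid on this ring, would shift the number beyond the scatter. All three compounds also share the same core, so they say nothing about changes made elsewhere in the structure.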